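The compounds below may be only part of what the source reports. "The series", "measured", "known", "first", "only" and "open" are said of these compounds alone.

Compound 1 `COc1ccc([C@H](O)[C@H]2CO[C@@H](c3ccc(OC)c(OC)c3)[C@H](C/C=C/c3ccccc3)C2)cc1OC`, compound 2 `COc1ccc(/C=C/C[C@@H]2C[C@@H]([C@@H](O)c3ccc(OC)c(OC)c3)CO[C@H]2c2ccc(OC)c(OC)c2)cc1` and compound 3 `COc1cccc([C@H](O)[C@H]2CO[C@H](c3ccc(OC)c(OC)c3)[C@@H](C/C=C/c3ccc(OC)c(OC)c3)C2)c1` were tested in a functional assay on HeLa cells (Homo sapiens) for cytotoxicity, read by WST assay, with a stated time of 48 h; a higher number here means a weaker inhibitor, a lower number a stronger inhibitor. Compound 1 gives 16100 nM, compound 2 gives 17100 nM, and compound 3 gives 21200 nM. One single change, (hydrogen in place of methoxy on an aromatic carbon), produced the step of a 1.1-fold lower number from compound 2 to compound 1 (0.03 log units; within the scatter). Compound 3 and compound 2 hold the same atoms joined differently, and the difference between their cores is not broken down here.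

Compound 4 `COc1ccc(/C=C/C[C@H]2C[C@@H]([C@@H](O)c3ccccc3)CO[C@@H]2c2ccc(OC)c(OC)c2)cc1OC` has not yet been measured in this assay. It differs from compound 3 by hydrogen in place of methoxy on an aromatic carbon. Among the compounds with values here, this is the same kind of change as the one between compound 2 and compound 1, though there the hydrogen enters para to a large group and here meta to a large group. Because the earlier step of a 1.1-fold lower number from compound 2 to compound 1 (0.03 log units; within the scatter) was small, a similarly small step is expected: a 1.1-fold lower number from compound 3 to compound 4 (0.03 log units; within the scatter). Compound 4 is therefore estimated at 20000 nM in this assay, with a likely range from 10000 nM to 40000 nM.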

Compound 4, half-maximal inhibitory concentration: 15500 nM
Compound 4: middle estimate off by 1.3-fold (0.11 log units), on the high side; measured number inside the range.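

In this assay, putting hydrogen in place of methoxy gives a 1.4-fold lower number from compound 3 to compound 4 (0.14 log units; within the scatter), and this step can be set beside the same change on the other core: the same change on two cores in this assay, a 1.1-fold lower number (0.03 log units; within the scatter) from compound 2 to compound 1 and a 1.4-fold lower number (0.14 log units; within the scatter) from compound 3 to compound 4, 1.3-fold (0.11 log units) apart, within the scatter of two such steps. In these two pairs, then, the change carries from one core to the other without a detectable difference, and neither step can be told apart from the scatter of repeated measurements. Two pairs do not show that the change would behave this way on other cores, nor that it has any real effect here.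

The compounds shown leave open what other groups on these aromatic rings, such as a fluorine atom or an amine, would do. They also leave open whether a carbonyl in place of the hydroxy group would change the number.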